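This account rests on a few compounds, and the source may have more. Where it says the series, first, only, none or still open, it means among the compounds named here.

Of the compounds shown here, two carry numbers so far: compound 1 `c1ccc(OC2CC2)c(OCC2=NCCN2)c1` and compound 2 `CCCc1ccccc1OC(C)C1=NCCN1`. In an assay on isolated protein for agonist activity at Alpha-2B adrenergic receptor (Homo sapiens) (a lower number here means that less compound is needed, a higher number that more compound is needed for the effect), compound 1 gives 3160 nM, while compound 2 gives 5010 nM. Compound 1 thus holds the lowest of the two numbers, yet compound 2 sits within the scatter of it, so the two values tell of no real difference between them.

Compound 3 `Brc1ccccc1OCC1=NCCN1` has not yet been measured in this assay. Set against compound 1, it differs in a single place: bromo in place of cyclopropyloxy on an aromatic carbon. For the measured compounds named here, no pair of measured compounds shows a change of this kind, so there is no step to lean on, and the two values at hand give no hint of how a small halogen at that position behaves in this assay.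

The step from compound 1 to compound 3 is therefore expected to be small, a 2.0-fold lower number from compound 1 to compound 3 (0.30 log units; within the scatter), leaning toward a lower number but not reliably beyond the scatter. Compound 3 is expected to give 1600 nM in this assay, within a range from 300 nM to 8000 nM.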

Compound 3, half-maximal effective concentration: 1260 nM
The estimate for compound 3 lay 1.3-fold (0.10 log units) above the measured number; measured number inside the range.
By their numbers in this assay, from the lowest: compound 3; then compounds 1 and 2 (each within the scatter of the next).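

For the compounds shown here, the change from cyclopropyloxy to bromo on this aromatic carbon gives, in this assay, a 2.5-fold lower number from compound 1 to compound 3 (0.40 log units; beyond the scatter) as the first step here that lies beyond the scatter, though it is only a modest one. It shows that this place does not depend on the cyclopropyloxy: the three-membered ring, the oxygen and its hydrogen-bond acceptor all leave, a single bromine enters, and the number falls rather than rises. No measurement at hand accounts for this step.

Going by these compounds, with a single pair, it remains open whether the step comes from the departure of the cyclopropyloxy, from the arrival of the bromo, or from both together. The compounds shown also leave open how this same place would respond to another halogen such as chloro or fluoro, to a plain methoxy, or to an amine or a carboxylic acid, so the reach of this one change across other groups on that carbon stays unknown for now.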